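The source may report more compounds than this note shows. Statements on the series, on what has been measured and on what is new or still open speak of the compounds shown alone.

Measured so far in a functional assay on HT-29 cells (Homo sapiens) for cytotoxicity, read by MTT assay, with a stated time of 72 h; a higher number here means a weaker inhibitor, a lower number a stronger inhibitor: compound 1 `COc1cc2c(Oc3ccc(NC(=O)c4cn(-c5ccccc5)nn4)cc3F)ccnc2cc1OCCCN1CCCC1` gives 180 nM; compound 2 `COc1cc2c(Oc3ccc(NC(=O)c4cn(-c5ccccc5C)nn4)cc3F)ccnc2cc1OCCCN1CCCC1` gives 1200 nM; compound 3 `COc1cc2c(Oc3ccc(NC(=O)c4cn(-c5ccccc5C)nn4)cc3F)ccnc2cc1OCCCN1CCC(C)CC1` gives 2380 nM.

Compound 4 `COc1cc2c(Oc3ccc(NC(=O)c4cn(-c5c(C)cccc5C)nn4)cc3F)ccnc2cc1OCCCN1CCC(C)CC1` has not been measured in this assay. The change from compound 3 to compound 4 is methyl in place of hydrogen on an aromatic carbon. The same kind of change was measured once before, from compound 1 to compound 2: methyl in place of hydrogen on an aromatic carbon. There the step was a 6.7-fold higher number from compound 1 to compound 2 (0.82 log units; beyond the scatter). The places are not identical: in the earlier pair the place was ortho to a large group only, whereas in compound 4 the place is also meta to a methyl group. The difference between the core of compound 1 and the core of compound 3 is not broken down here; the step from compound 2 to compound 3 was a 2.0-fold higher number from compound 2 to compound 3 (0.30 log units; within the scatter).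

Because the earlier step was a 6.7-fold higher number from compound 1 to compound 2 (0.82 log units; beyond the scatter), a further loss is expected for compound 4, estimated as a 2.9-fold higher number from compound 3 to compound 4 (0.47 log units; beyond the scatter), though the second methyl on the same ring may not repeat the full size. Compound 4 is estimated at 7000 nM, with a range from 2500 nM to 25000 nM.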

Compound 4, half-maximal inhibitory concentration: 2450 nM
Estimate against measurement, compound 4: 2.9-fold (0.46 log units) above, outside the stated range (below it).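

The change from 2-methylphenyl to 2,6-dimethylphenyl in this assay gave a 1.0-fold higher number from compound 3 to compound 4 (0.01 log units; within the scatter) and did not repeat the earlier step seen on the other core. This rests on a single pair from each core, and the new methyl in compound 4 is also meta to a methyl group, so the comparison cannot separate the effect of the core from that of the place on the ring. It does show that, in this series, the size of this step did not carry over from one core to the other: the same change on two cores in this assay, a 6.7-fold higher number (0.82 log units; beyond the scatter) from compound 1 to compound 2 and a 1.0-fold higher number (0.01 log units; within the scatter) from compound 3 to compound 4, 6.5-fold (0.81 log units) apart, beyond the scatter of two such steps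

The compounds shown leave open how the 2,6-dimethylphenyl group behaves with pyrrolidin-1-yl in place of 4-methylpiperidin-1-yl. They also leave open whether a methoxy group, a chlorine atom or a carboxylic acid on the phenyl ring would follow methyl.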